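A few compounds are considered here, and "the series" means these few. Any claim that something is new, unique, unknown or untested is made for them only; others in the source may bear on it.

Working notes on the series:

- compound 1 `CCOC(=O)N1CCN(Cc2cc(Nc3nc(C)cn4c(-c5cn[nH]c5)cnc34)sn2)CC1` - 178 ng.h/mL
- compound 2 `CC(=O)N1CCN(Cc2cc(Nc3nc(C)cn4c(-c5cn[nH]c5)cnc34)sn2)CC1` - "not determined" (no result reported)
- compound 3 `Cc1cn2c(-c3cn[nH]c3)cnc2c(Nc2cc(CN3C[C@@H](C)O[C@@H](C)C3)ns2)n1` - 3100 ng.h/mL

In an ADME assay on the whole organism (plasma) for pharmacokinetics, with Rattus norvegicus as the target, with a stated time of 6 h, at a dose of 10 mg/kg by the oral route (a higher number here means more compound in the circulation at the dose given, a lower number less compound in the circulation), compound 3 holds the higher of the two numbers available, 3100 ng.h/mL, and compound 2 offers no comparison. Within the data shown here, the single measured step, a 17-fold higher number from compound 1 to compound 3 (1.24 log units; beyond the scatter), lies beyond the scatter. It brings in 2,6-dimethylmorpholin-4-yl in place of 4-(ethoxycarbonyl)piperazin-1-yl on a saturated chain carbon bound to an aromatic carbon.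

Compound 4 `Cc1cn2c(-c3cn[nH]c3)cnc2c(Nc2cc(CN3C[C@H](C)OC[C@@H]3C)ns2)n1` is the next entry to be read in this assay. The change is a group of 8 heavy atoms (6 carbon, 1 nitrogen, 1 oxygen; one six-membered non-aromatic ring with 2 hetero atoms) in place of a group of 8 heavy atoms (6 carbon, 1 nitrogen, 1 oxygen; one six-membered non-aromatic ring with 2 hetero atoms), on a saturated chain carbon bound to an aromatic carbon. The two compounds have the same atoms, joined differently, and the group that enters has no common name.

The measured step bears on this only indirectly. Among the measured compounds shown here, it shows that the number can move widely with the group at this place, but it exchanges two different groups, and no pair of isomers has been measured. A move as large as that one is therefore not assumed, although the uncertainty stays wide. The expected change is a small drop from compound 3 at 3100 ng.h/mL, not clearly beyond the scatter. The expected step is a 1.4-fold lower number from compound 3 to compound 4 (0.15 log units; within the scatter). For compound 4 the estimated value is 2200 ng.h/mL, with an expected range of 700 ng.h/mL to 6000 ng.h/mL.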

Compound 4, area under the concentration-time curve: 1660 ng.h/mL
Estimate against measurement, compound 4: 1.3-fold (0.12 log units) above; measured number inside the range.
By their numbers in this assay, from the lowest: compound 1; then compounds 4 and 3 (each within the scatter of the next).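

In this assay, among these compounds, this is the first pair of isomers at this place, on a saturated chain carbon bound to an aromatic carbon, and it gives a 1.9-fold lower number from compound 3 to compound 4 (0.27 log units; within the scatter); here, rejoining the same atoms, with the counts of heavy atoms, hydrogen-bond donors and hydrogen-bond acceptors unchanged, does not separate the two compounds. The comparison with the 4-(ethoxycarbonyl)piperazin-1-yl group now has a second member, a 9.3-fold higher number from compound 1 to compound 4 (0.97 log units; beyond the scatter), so the separation from compound 1 is no longer tied to 2,6-dimethylmorpholin-4-yl alone, although this step is read as modest where the step from that group to 2,6-dimethylmorpholin-4-yl is read as large. Nothing at hand gives a reason for either step or for the closeness of the two isomers.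

The compounds shown leave open whether the methyl groups or the ring oxygen are needed at this place, which unsubstituted morpholine and a piperidine would address. They also leave open whether an open-chain amine such as dimethylamine would stay with compounds 3 and 4 or fall nearer to compound 1.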